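Compound 1 to compound 3: bromo for fluoro

The compounds below may be only part of what the source reports. "The series", "measured", "known", "first", "only" and "open" are said of these compounds alone.

- compound 1 `CCO[C@H]1C[C@@H](c2coc3ccc(F)cc3c2=O)N(c2ccccc2)O1`: 26400 nM
- compound 2 `O=c1c([C@@H]2C[C@H](c3ccccc3)ON2c2ccccc2)coc2ccc(F)cc12`: 51500 nM

Within the data shown here, in a functional assay on A549 cells (Homo sapiens) for inhibition, read by sulforhodamine B assay, with a stated time of 48 h (on this read-out higher numbers stand for weaker inhibition and lower numbers for stronger inhibition), compound 1 gives 26400 nM, within the scatter of the only other measured compound. Compound 3 `CCO[C@H]1C[C@@H](c2coc3ccc(Br)cc3c2=O)N(c2ccccc2)O1` has bromo in place of fluoro on an aromatic carbon. Among the measured compounds shown here, the only measured step, a 2.0-fold higher number from compound 1 to compound 2 (0.29 log units; within the scatter), is phenyl in place of ethoxy on a saturated ring carbon, and no measured step changes the halogen. No step beyond the scatter is therefore expected in this assay, though the data give little support. The expected step is a 1.2-fold lower number from compound 1 to compound 3 (0.08 log units; within the scatter). Compound 3 is estimated at 22000 nM, with a range of 9000 nM to 50000 nM.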

Compound 3, half-maximal inhibitory concentration: 21500 nM
For compound 3 the middle estimate is 1.0-fold (0.01 log units) above the measured one; the measured number falls inside the stated range.
By their numbers in this assay, from the lowest: compounds 3, 1 and 2 (each within the scatter of the next, the first and the last beyond it).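

In this assay, among these compounds, the only measured step at the halogen is a 1.2-fold lower number from compound 1 to compound 3 (0.09 log units; within the scatter), with bromo in place of fluoro on an aromatic carbon. With ethoxy kept, this position therefore carries either halogen without a change beyond the scatter. Nothing available bears on the reason for this result.

From the compounds shown here alone, whether a non-halogen group at this carbon, such as an amine or a carboxylic acid, would move the number remains open. So does whether bromo gives the same outcome with phenyl in place of ethoxy on the saturated ring carbon.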